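The source may report more compounds than this note shows. Statements on the series, on what has been measured and on what is new or still open speak of the compounds shown alone.

Series overview, measured in a functional assay on U-251 cells (Homo sapiens) for inhibition, read by sulforhodamine B assay, with a stated time of 48 h, tested at 0.01 uM; a lower number here means a stronger effect, a higher number a weaker effect of the compound at the concentration tested:

Compound 1, `COc1cc(Cl)cc(-c2nn(-c3cccc(NC(=O)Nc4ccc(Cl)c(C(F)(F)F)c4)c3)cc2-c2ccncc2)c1`: 98%
Compound 2, `COc1cc(Cl)cc(-c2nn(-c3cccc(NC(=O)Nc4ccc(Cl)c(Cl)c4)c3)cc2-c2ccncc2)c1`: 95%
Compound 3, `COc1cc(Cl)cc(-c2nn(-c3cccc(NC(=O)Nc4cccc(C(F)(F)F)c4)c3)cc2-c2ccncc2)c1`: 95%

Compound 3 sits level with compound 2 at the digits given, the two together at the low end of the three numbers; one of its steps is a number 3 percentage points lower from compound 1 to compound 3 (within the scatter), and the other is no change at the digits printed from compound 2 to compound 3 (within the scatter). Within the data shown here, the only other step, a number 3 percentage points lower from compound 1 to compound 2 (within the scatter), is likewise small. All three measured steps concern the aryl group on the amide-type nitrogen and none crosses the scatter.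

Compound 4, `COc1cc(Cl)cc(-c2nn(-c3cccc(NC(=O)c4cccc(C(F)(F)F)c4)c3)cc2-c2ccncc2)c1`, differs from compound 3 in 3-(trifluoromethyl)phenyl in place of (3-(trifluoromethyl)phenyl)amino on a carbonyl carbon. Among the measured compounds shown here, no measured step touches the carbonyl carbon or the (3-(trifluoromethyl)phenyl)amino unit itself, so nothing here speaks directly to this change; the three small steps seen so far suggest the series is not very sensitive to changes at this end, but that is a weak basis. The step from compound 3 to compound 4 is expected to be a number 2 percentage points lower from compound 3 to compound 4 (within the scatter) in this assay. Compound 4 is therefore estimated at 93%, with a range from 75% to 100%.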

Compound 4, a percentage reported as activity, at one concentration (the size of the read-out at that concentration, not a potency): 94%
Compound 4: middle estimate off by 1 percentage points, on the low side, within the range that was stated.
By their numbers in this assay, from the lowest: compounds 4, 2, 3 and 1 (each within the scatter of the next).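

In this assay, among these compounds, the change on the carbonyl carbon takes out the nitrogen and hydrogen-bond donor of the (3-(trifluoromethyl)phenyl)amino unit and gives a number 1 percentage points lower from compound 3 to compound 4 (within the scatter), the first step to alter the link to the aryl group rather than the aryl group alone. The two further steps to the same compound, a number 1 percentage points lower from compound 2 to compound 4 (within the scatter) and a number 4 percentage points lower from compound 1 to compound 4 (within the scatter), also stay within the scatter, so in this read-out at this single concentration the series shows no measurable dependence on that nitrogen. Nothing available accounts for this result or separates a real absence of effect from a read-out that cannot resolve one.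

On these data alone, all four compounds carry a chloro- or trifluoromethyl-substituted phenyl at this end, so it remains open whether a saturated amine, a carboxylic acid or a longer alkyl chain on the carbonyl carbon would move the number beyond the scatter. The results also leave open whether the link matters at other concentrations, where a difference hidden here might appear.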